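The compounds below may be only part of what the source reports. "The series", "measured", "known", "first", "only" and "open" are said of these compounds alone.

Measured compounds:
compound 1 `COC(=O)[C@@]1(C)CC[C@@H]2C3=C1CC[C@@H](C)[C@]3(C)C[C@@H]1c3ccccc3N[C@H]21` — 35000 nM
compound 2 `COC(=O)[C@@]1(C)CC[C@@H]2C3=C1CC[C@@H](C)[C@]3(C)C[C@@H]1c3cc(C)ccc3N[C@H]21` — 23000 nM
compound 3 `COC(=O)[C@@]1(C)CC[C@@H]2C3=C1CC[C@@H](C)[C@]3(C)C[C@@H]1c3cc(Cl)ccc3N[C@H]21` — 28000 nM

In a functional assay on T47D cells (Homo sapiens) for inhibition, read by sulforhodamine B assay, with a stated time of 48 h (on this read-out lower numbers stand for stronger inhibition of growth and higher numbers for weaker inhibition of growth), compound 1 gives 35000 nM, the highest of the three numbers. The gap is small on either side: a 1.3-fold lower number from compound 1 to compound 3 (0.10 log units; within the scatter) and a 1.5-fold lower number from compound 1 to compound 2 (0.18 log units; within the scatter), so the three compounds stand together rather than apart.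

Compound 4 `COC(=O)[C@@]1(C)CC[C@@H]2C3=C1CC[C@@H](C)[C@]3(C)C[C@@H]1c3cccc(Br)c3N[C@H]21` differs from compound 1 in one place: bromo in place of hydrogen on an aromatic carbon. Within the data shown here, no bromo compound has been measured, so the nearest guide comes from the two other substitutions on an aromatic carbon of the shared core, methyl in compound 2 and chloro in compound 3. Both gave a 1.5-fold lower number from compound 1 to compound 2 (0.18 log units; within the scatter) and a 1.3-fold lower number from compound 1 to compound 3 (0.10 log units; within the scatter), neither beyond the scatter, and a 1.2-fold higher number from compound 2 to compound 3 (0.09 log units; within the scatter) shows the two substituents to be indistinguishable here. On this basis no step beyond the scatter is expected from compound 1 to compound 4 in this assay. Compound 4 is therefore estimated at 28000 nM, with a range of 12000 nM to 65000 nM, which corresponds to an expected 1.3-fold lower number from compound 1 to compound 4 (0.10 log units; within the scatter).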

Compound 4, concentration for 50% growth inhibition: 37000 nM
The estimate for compound 4 lay 1.3-fold (0.12 log units) below the measured number, within the range that was stated.
By their numbers in this assay, from the lowest: compounds 2, 3, 1 and 4 (each within the scatter of the next).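

In this assay, placing bromo on this aromatic carbon, ortho to a fused ring and meta to a fused ring, gives a 1.1-fold higher number from compound 1 to compound 4 (0.02 log units; within the scatter), so a bromo at this carbon brings no step beyond the scatter. The earlier steps shown here covered only methyl in compound 2 and chloro in compound 3, each on a different aromatic carbon from this one, so compound 4 extends the same flat result to a third group and a second carbon of the ring. No measurement at hand accounts for this result.

Going by these compounds, whether an amine, a carboxylic acid or a longer chain on this carbon would move the number beyond the scatter remains open. On these data alone, it is also open whether any substituent on this ring of the shared core can shift growth inhibition at all, since all three steps from compound 1 stay within the scatter.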